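The source may report more compounds than this note shows. Statements on the series, on what has been measured and on what is new or still open speak of the compounds shown alone.

Working notes on the series. For the measured compounds named here, compound 1 `Cn1c(I)nc2ccccc21` is the only member with a numeric read-out: in a functional assay on NCI-H522 cells (Homo sapiens) for cytotoxicity, with a stated time of 3 days (on this read-out lower numbers stand for stronger inhibition and higher numbers for weaker inhibition), compound 1 gives 1020 nM. Compound 2 `C=Cc1nc2ccccc2s1` stands at a limit of this assay, compound 2 giving > 40000 nM. Compound 3 `C=Cc1csc(Br)n1` likewise sits at a limit, compound 3 giving > 40000 nM. Two of the three values shown thus rest at the limit of > 40000 nM in this assay, at which 2 of the 3 values shown sit. Going by the values given here, compound 2 therefore has no number of its own, only that limit, and the single numeric value of compound 1 offers no measured step to set beside it. Among the compounds with values here, no two measured compounds differ in one place, so no measured step is available.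

Compound 4 `CC#Cc1nc2ccccc2s1` remains to be measured in this assay. It differs from compound 2 in one place: prop-1-yn-1-yl in place of vinyl on an aromatic carbon. With compound 2 resting at a limit, the direction of the step cannot be read from the data, and neither a step within the scatter nor one beyond it can be ruled out. The step expected from compound 2 to compound 4 is a step that the limit leaves unreadable from compound 2 to compound 4, that is, no movement beyond the scatter. Compound 4 is expected to give about 45000 nM, within a range from 15000 nM to 150000 nM, with a strong chance that this assay again reports only a limit.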

Compound 4, half-maximal inhibitory concentration: > 40000 nM
Compound 4: no number, only a limit; the forecaster's own chance of this, stated with the estimate: 75%; the middle value is on the limit's open side.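

Compound 2 and compound 4 both rest at a limit rather than at a number, so no step can be read between them: the limit of > 40000 nM in this assay, at which 3 of the 4 values shown sit. The compounds shown leave open whether prop-1-yn-1-yl in place of vinyl on an aromatic carbon changes the read-out at all in this assay.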